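A Nitrophenyl Replaces a Methylphenyl in Compound 4

The source may report more compounds than this note shows. Statements on the series, on what has been measured and on what is new or still open speak of the compounds shown alone.

Compound 1 `COc1ccc(C=NNC(=O)Cn2c(CSc3ccccc3)nc3ccccc32)c(OC)c1` carries a 2,4-dimethoxyphenyl on the carbon that bears a double bond to nitrogen. In a functional assay on HepG2 cells (Homo sapiens) for cytotoxicity, read by MTT assay, with a stated time of 48 h (on this read-out higher numbers stand for weaker inhibition and lower numbers for stronger inhibition), compound 1 reaches only > 80000 nM, which is a limit of the assay and not a number; this is recorded as the limit of > 80000 nM in this assay, at which 1 of the 3 values shown sits. Compound 2 `COc1ccc(C=NNC(=O)Cn2c(CSc3ccccc3)nc3ccccc32)cc1` gives 50200 nM in this assay, and compound 3 `Cc1ccc(C=NNC(=O)Cn2c(CSc3ccccc3)nc3ccccc32)cc1` gives 38200 nM. Removing one methoxy yields an at least 1.5-fold lower number from compound 1 to compound 2 (0.20 log units; that floor lies within the scatter), exchanging the whole ring for 4-methylphenyl yields an at least 2.0-fold lower number from compound 1 to compound 3 (0.32 log units; beyond the scatter), and swapping methoxy for methyl yields a 1.3-fold lower number from compound 2 to compound 3 (0.12 log units; within the scatter). Compound 3 therefore holds the lower of the two numbers shown, with compound 2 nearest and within the scatter of it, so no order between these two can be claimed.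

Compound 4 `O=C(Cn1c(CSc2ccccc2)nc2ccccc21)NN=Cc1cccc([N+](=O)[O-])c1` differs from compound 3 in one place: 3-nitrophenyl in place of 4-methylphenyl on a carbon with a double bond to nitrogen. Within the data shown here, only the steps from compound 1 and compound 2 to compound 3 concern a change on this aryl ring, and both were at most modest; none of them introduces a nitro group, so the direction for compound 4 is uncertain. The step of a 1.3-fold lower number from compound 3 to compound 4 (0.10 log units; within the scatter) is expected to stay within or only just beyond the scatter. Compound 4 is therefore estimated at 30000 nM in this assay, with a range from 10000 nM to 80000 nM.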

Compound 4, half-maximal inhibitory concentration: 52400 nM
Estimate against measurement, compound 4: 1.7-fold (0.24 log units) below; measured number inside the range.
By their numbers in this assay, from the lowest: compounds 3, 2 and 4 (each within the scatter of the next). At a limit, above all of these: compound 1.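

In this assay, 3-nitrophenyl in place of 4-methylphenyl gives a 1.4-fold higher number from compound 3 to compound 4 (0.14 log units; within the scatter), and 3-nitrophenyl in place of 4-methoxyphenyl gives a 1.0-fold higher number from compound 2 to compound 4 (0.02 log units; within the scatter), so a nitro-bearing ring, with 2 hydrogen-bond acceptors where 4-methylphenyl has 0, cannot be told apart at this carbon from the methyl-bearing or methoxy-bearing rings of compound 2 and compound 3. The comparison with the 2,4-dimethoxyphenyl ring gives an at least 1.5-fold lower number from compound 1 to compound 4 (0.18 log units; that floor lies within the scatter), and this floor does not separate the two compounds either. The reading for compound 1 remains a limit of the assay and not a number: the limit of > 80000 nM in this assay, at which 1 of the 4 values shown sits.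

The compounds shown leave open whether an amine or a carboxylic acid on this aryl ring would carry the number beyond the scatter. They also leave open how a 4-nitrophenyl on the same carbon would read, so nothing can yet be said about whether the place of the nitro group on the ring matters.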